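A few compounds are considered here, and "the series" means these few. Any claim that something is new, unique, unknown or untested is made for them only; others in the source may bear on it.

In a functional assay on CHO cells for agonist activity at Alpha-2C adrenergic receptor (Homo sapiens) (on this read-out higher numbers stand for larger maximal responses and lower numbers for smaller maximal responses), the compounds here share a core in which a five-membered non-aromatic ring sits on a saturated chain carbon bound to an oxygen on an aromatic ring and a saturated chain carbon. Compound 3 `CC(Oc1ccccc1-c1ccccc1)C1=NCCS1` reaches only a limit in this assay, < 0.3. Compound 1 `CC(Oc1ccccc1-c1ccccc1)C1=NCCO1` likewise reaches only a limit, < 0.3. Compound 2 `Cc1ccccc1-c1ccccc1OC(C)C1=NCCN1` gives a readable number in this assay, 0.45. Going by the values given here, the single step between measured neighbours, a step that the two limits leave unreadable from compound 1 to compound 3, has no readable size because both ends sit at the limit of < 0.3 in this assay, at which 2 of the 3 values shown sit.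

Compound 4 `CC(Oc1ccccc1-c1ccccc1)C1=NCCC1` differs from compound 3 by a group of 5 heavy atoms (4 carbon, 1 nitrogen; one five-membered non-aromatic ring with 1 hetero atom) in place of a group of 5 heavy atoms (3 carbon, 1 nitrogen, 1 sulfur; one five-membered non-aromatic ring with 2 hetero atoms), on a saturated chain carbon bound to an oxygen on an aromatic ring and a saturated chain carbon. Among the compounds with values here, no measured step removes the sulfur from this ring, so the change has no direct precedent. The two rings with two hetero atoms in compound 1 and compound 3 both stop at the limit of < 0.3 in this assay, at which 2 of the 3 values shown sit. Only compound 2 gives a readable number, 0.45. Compound 4 keeps a single nitrogen and no second hetero atom, so a step of small size is expected, a step that the limit leaves unreadable from compound 3 to compound 4, with a real chance that the assay again reports only a limit. Compound 4 is therefore estimated at 0.25, between 0.1 and 0.45.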

Compound 4, intrinsic activity: the largest response reached, as a fraction of the reference agonist's: < 0.3
Compound 4 ended at the assay's limit (the forecaster's own chance of this, stated with the estimate: 60%); the middle value lies beyond the limit too.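

In this assay compound 4 gives < 0.3, which is a limit of the assay and not a number. The steps to compound 4 from compound 1 and from compound 3 cannot be read, because all three compounds stop at the same limit: the limit of < 0.3 in this assay, at which 3 of the 4 values shown sit.

The compounds shown leave open whether the rings in compound 1, compound 3 and compound 4 differ at all in maximal response.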